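An Ester Link Replaces an Ether in a Selenocyanate Chain

This account rests on a few compounds, and the source may have more. Where it says the series, first, only, none or still open, it means among the compounds named here.

Compound 2 `COc1ccc(N(C)c2nc(C)nc3ccccc23)cc1OCCCCC[Se]C#N` is examined in a functional assay on LoVo cells (Homo sapiens) for inhibition, read by MTT assay, with a stated time of 48 h; a higher number here means a weaker inhibitor, a lower number a stronger inhibitor. Among the three compounds measured, compound 2 gives 5210 nM, the highest number of the set. Compound 1 `COc1ccc(N(C)c2nc(C)nc3ccccc23)cc1OCCN` gives 421 nM in this assay, and compound 3 `Cc1nc(N(C)c2ccc([Se]C#N)c(F)c2)c2ccccc2n1` gives 13 nM. For the measured compounds named here, the only single-point step recorded is a 12-fold higher number from compound 1 to compound 2 (1.09 log units; beyond the scatter). Compound 4 `COc1ccc(N(C)c2nc(C)nc3ccccc23)cc1C(=O)OCCCC[Se]C#N` differs from compound 2 as follows: a group of 10 heavy atoms (6 carbon, 1 nitrogen, 2 oxygen, 1 selenium; no ring) in place of a group of 9 heavy atoms (6 carbon, 1 nitrogen, 1 oxygen, 1 selenium; no ring), on an aromatic carbon. Going by the values given here, no measured step tells how this change plays out: the step from compound 1 to compound 2 concerns a different substitution, and compound 3 carries no such chain at all, so no pair bears directly on the swap of an ether-linked chain for an ester-linked one. With nothing to argue for a move in either direction, the step of a 1.2-fold lower number from compound 2 to compound 4 (0.06 log units; within the scatter) is expected to fall within the scatter. The estimate for compound 4 is therefore 4500 nM, with a range from 1500 nM to 13000 nM.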

Compound 4, half-maximal inhibitory concentration: 1080 nM
Beside the measured number, compound 4's estimate is 4.2-fold (0.62 log units) above it; the measured number lies below the stated range.
By their numbers in this assay, from the lowest: compound 3; then compound 1; then compound 4; then compound 2.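

In this assay, the aromatic carbon ortho to a methoxy group responds to the way the selenocyanate chain is attached: replacing the ether-linked chain with the ester-linked one gives a 4.8-fold lower number from compound 2 to compound 4 (0.68 log units; beyond the scatter) and so moves the number beyond the scatter. The ester-linked chain still does not match the other group at the same place, as the change gives a 2.6-fold higher number from compound 1 to compound 4 (0.41 log units; beyond the scatter) and remains a modest step beyond the scatter. No evidence is available to explain either step.

The compounds shown leave open whether an amide or a carboxylic acid at this aromatic carbon would lower the number further. They also leave open how a longer chain behind the ester, or a thiocyanate in place of the selenocyanate, would register in this assay.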